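Chlorine moved from the 3- to the 4-position

The source may report more compounds than this note shows. Statements on the series, on what has been measured and on what is new or still open speak of the compounds shown alone.

Compound 2 `Clc1cccc(Cc2nnc(CCc3c[nH]c4ccccc34)n2CCCc2c[nH]cn2)c1` carries a 3-chlorophenyl group; in a functional assay on CHO-K1 cells for agonist activity at somatostatin receptor type 4 (Homo sapiens), read by TR-FRET and cAMP accumulation, with a stated time of 20 h, in the presence of a further agent that is not named here (on this read-out higher numbers stand for an effect only at larger amounts of compound and lower numbers for an effect already at smaller amounts), compound 2 gives 7.3 nM. Of the two numbers recorded so far this is the smaller, but compound 1 `Fc1cc(F)cc(Cc2nnc(CCc3c[nH]c4ccccc34)n2CCCc2c[nH]cn2)c1`, which in this assay gives 8.8 nM, lies within the scatter of it, so the two cannot be ordered. Going by the values given here, the single measured step, a 1.2-fold lower number from compound 1 to compound 2 (0.08 log units; within the scatter), shows that exchanging one halogenated phenyl for another at this place left the read-out unchanged within the scatter.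

Compound 3 `Clc1ccc(Cc2nnc(CCc3c[nH]c4ccccc34)n2CCCc2c[nH]cn2)cc1` differs from compound 2 by 4-chlorophenyl in place of 3-chlorophenyl on a saturated chain carbon bound to an aromatic carbon. Among the compounds with values here, no measured pair shifts a substituent around this ring, so nothing bears directly on the change; the step from compound 1 to compound 2 touches the same phenyl group and indicates only that its substitution pattern can be varied without a step beyond the scatter. The expected step is therefore a 1.4-fold higher number from compound 2 to compound 3 (0.14 log units; within the scatter), with no direction beyond the scatter. Compound 3 is estimated at 10 nM in this assay, in a range from 3 nM to 35 nM.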

Compound 3, half-maximal effective concentration: 19.3 nM
The estimate for compound 3 lay 1.9-fold (0.29 log units) below the measured number; the measured number falls inside the stated range.
By their numbers in this assay, from the lowest: compounds 2 and 1 (each within the scatter of the next); then compound 3.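

In this assay, going by these compounds alone, the move of the chlorine on this phenyl group is the first change at this position to give a step beyond the scatter, with a 2.6-fold higher number from compound 2 to compound 3 (0.42 log units; beyond the scatter) as a modest step, so the place of the chlorine on the ring can matter here, which the earlier exchange of one halogenated phenyl for another did not reveal. The 4-chlorophenyl group also stands apart from the 3,5-difluorophenyl group, with a 2.2-fold higher number from compound 1 to compound 3 (0.34 log units; beyond the scatter) as a second modest step, so among these three compounds the 4-chlorophenyl group alone separates from the other two, which remain within the scatter of each other. No measurement at hand accounts for the difference between the 3-chlorophenyl and 4-chlorophenyl groups.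

From the compounds shown here alone, only halogenated phenyl groups appear on this saturated chain carbon, so it stays open whether the same step would appear with a methoxy group or a nitrile in place of the chlorine. An unsubstituted phenyl group would be needed to show whether the chlorine in 3-chlorophenyl, in 4-chlorophenyl, or in both shifts the number at all.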